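The compounds below may be only part of what the source reports. "The series", "measured", "known", "first", "only" and "open" are said of these compounds alone.

In an assay for inhibition of very long chain fatty acid elongase 6 (Homo sapiens) (a lower number here means a stronger inhibitor, a higher number a weaker inhibitor), the three measured compounds stand as follows:

compound 3 `O=C1Nc2ccc(Cl)cc2C(CNC(=O)c2cccc(F)c2)(C(F)(F)F)O1`: 261 nM
compound 2 `O=C(Nc1ccc(F)cc1)OCC1(C2CC2)OC(=O)Nc2ccc(Cl)cc21`: 1410 nM
compound 1 `CC(C)C1(COC(=O)Nc2ccc(F)cc2)OC(=O)Nc2ccc(Cl)cc21`: 5030 nM

Compound 3 gives the lowest number of the three; compound 2 gives a higher number, and compound 1 gives a higher number still. Compound 4 `O=C1Nc2ccc(Cl)cc2C(CNC(=O)c2ccc(C(F)(F)F)cc2)(C(F)(F)F)O1` is not yet measured. It differs from compound 3 in one place: 4-(trifluoromethyl)phenyl in place of 3-fluorophenyl on a carbonyl carbon. Among the compounds with values here, no measured pair shows this kind of change. Within the data shown here, the only measured step, a 3.6-fold lower number from compound 1 to compound 2 (0.55 log units; beyond the scatter), concerns a group on a saturated ring carbon of the shared core, not the aryl group bound to the carbonyl carbon, so it gives no direct guidance on the change from compound 3 to compound 4. Among the measured compounds shown here, with no step of the same kind in hand, the expectation for compound 4 rests on compound 3 alone, and the expected step is a 1.1-fold higher number from compound 3 to compound 4 (0.06 log units; within the scatter), which is not beyond the scatter in either direction. Compound 4 is therefore estimated to give 300 nM, within a range from 80 nM to 1200 nM.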

Compound 4, half-maximal inhibitory concentration: 813 nM
Compound 4: the middle estimate sits 2.7-fold (0.43 log units) below what was measured; the range from low to high includes it.
By their numbers in this assay, from the lowest: compound 3; then compounds 4 and 2 (each within the scatter of the next); then compound 1.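

In this assay, the result shows that the aryl group on the carbonyl carbon is not a silent place: 4-(trifluoromethyl)phenyl in place of 3-fluorophenyl gives a 3.1-fold higher number from compound 3 to compound 4 (0.49 log units; beyond the scatter) and so moves the series toward weaker inhibition. Within the data shown here, the earlier step concerned only a group on a saturated ring carbon, so this is the first sign that the number also responds to a change at the aryl group. Nothing shown here gives a reason for this step.

The two group names differ in both the substituent and its number, so the compounds shown cannot separate those two changes. They also leave open how plain phenyl, or a ring carrying a nitrile or a methoxy group, would behave at this place.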